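A few compounds are considered here, and "the series" means these few. Any claim that something is new, unique, unknown or untested is made for them only; others in the source may bear on it.

Measured compounds in a functional assay on HeLa cells for agonist activity at 5-hydroxytryptamine receptor 6 (Homo sapiens), read by cAMP accumulation and immunoassay; on this read-out lower numbers stand for smaller maximal responses and higher numbers for larger maximal responses:

compound 1, `O=S(=O)(c1ccccc1)c1cn(C2CCCNC2)c2ncccc12` — 56%
compound 2, `O=S(=O)(c1cccc(Cl)c1)c1cn(C2CCCNC2)c2ncccc12` — 49%
compound 3, `O=S(=O)(c1cccc(Br)c1)c1cn(C2CCCNC2)c2ncccc12` — 49%

On these numbers compound 3 stands level with compound 2 at the digits shown, the two of them together the lowest of the three; the gap to compound 1 is a step of a number 7 percentage points lower from compound 1 to compound 3 (within the scatter), which lies within the scatter, so no order among the three can be read from the values.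

Compound 4, `O=S(=O)(c1cc(Cl)cc(Cl)c1)c1cn(C2CCCNC2)c2ncccc12`, is not yet measured. It differs from compound 3 in one place: 3,5-dichlorophenyl in place of 3-bromophenyl on a sulfonyl sulfur. For the measured compounds named here, three measured steps bear on this change. Putting a chloro or a bromo on an aromatic carbon of the shared core gave a number 7 percentage points lower from compound 1 to compound 2 (within the scatter) and a number 7 percentage points lower from compound 1 to compound 3 (within the scatter), and exchanging bromo for chloro gave no change at the digits printed from compound 2 to compound 3 (within the scatter). None of them left the scatter. Going by the values given here, a second halogen on the same ring has no measured precedent here, so the expectation rests on the first halogen having mattered little. Compound 4 is therefore expected to give a step of a number 4 percentage points lower from compound 3 to compound 4 (within the scatter), at most a small lowering and possibly none beyond the scatter. The estimate for compound 4 in this assay is 45%, with a range from 30% to 60%.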

Compound 4, largest response reached (Emax), in percent of the reference or control that the assay uses: 62%
Compound 4: middle estimate off by 17 percentage points, on the low side; the measured number lies above the stated range.
By their numbers in this assay, from the lowest: compounds 2, 3, 1 and 4 (each within the scatter of the next, the first and the last beyond it).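

At this place, on a sulfonyl sulfur, the 3,5-dichlorophenyl group produced the first differences beyond the scatter in this assay: a number 13 percentage points higher from compound 3 to compound 4 (beyond the scatter), set against the 3-bromophenyl group, and a number 13 percentage points higher from compound 2 to compound 4 (beyond the scatter), where one further chloro takes the place of a hydrogen on an aromatic carbon. The change from phenyl itself, however, is only a number 6 percentage points higher from compound 1 to compound 4 (within the scatter), so the compounds with one halogen and the compound with two chloro groups can be told apart from each other, while compound 1 cannot be told apart from any of them, and the ring on the sulfonyl sulfur can no longer be read as indifferent to halogens. Nothing available explains this difference between one halogen and two.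

As far as these compounds go, with a single compound carrying two substituents on this ring, it remains open whether the difference follows the second halogen or belongs to 3,5-dichlorophenyl alone. A 3,5-dibromophenyl, 3,5-difluorophenyl or 3,5-dimethoxyphenyl group on the sulfonyl sulfur would test how far it extends beyond chloro.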